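Aminopyrazine in place of thiophene amide on the chain nitrogen

A few compounds are considered here, and "the series" means these few. Any claim that something is new, unique, unknown or untested is made for them only; others in the source may bear on it.

For the measured compounds named here, compound 2 `CCN1CCN(c2cccc3c2CN([C@H](CCCNC(=O)c2cccs2)c2ccc(OC)c(OC)c2)C3=O)CC1` gives 7 nM in a functional assay on CHO-K1 cells for antagonist activity at Urotensin-2 receptor (Rattus norvegicus), read by FLIPR and calcium flux, with a stated time of 1 h (on this read-out lower numbers stand for stronger inhibition and higher numbers for weaker inhibition), the lowest of the three numbers measured so far. Compound 1 `CCN1CCN(c2cccc3c2CN([C@H](CCCNS(=O)(=O)c2c[nH]cn2)c2ccc(OC)c(OC)c2)C3=O)CC1` gives 23 nM in this assay, and compound 3 `COc1ccc([C@@H](CCCN(C)S(=O)(=O)c2cccs2)N2Cc3c(cccc3N3CCNCC3)C2=O)cc1OC` gives 39 nM. Going by the values given here, the one single-point step available, a 3.3-fold lower number from compound 1 to compound 2 (0.52 log units; beyond the scatter), shows that the group carried by the amine nitrogen on the chain shifts the read-out beyond the scatter. Among the compounds with values here, compound 3 differs from compound 2 in more than one place and offers no clean step.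

Compound 4 `CCN1CCN(c2cccc3c2CN([C@H](CCCNc2cncc(OC)n2)c2ccc(OC)c(OC)c2)C3=O)CC1` carries the change (6-methoxypyrazin-2-yl in place of (thiophen-2-yl)carbonyl on an amine nitrogen). Within the data shown here, no measured step covers an aromatic ring bound directly to this nitrogen in place of a carbonyl- or sulfonyl-linked group; that step only indicates the position is sensitive, and its direction cannot be carried over. Taking compound 2 as the anchor, a modest weakening is expected, a 2.9-fold higher number from compound 2 to compound 4 (0.46 log units; beyond the scatter). Compound 4 is therefore estimated at 20 nM in this assay, with a range of 6 nM to 70 nM.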

Compound 4, half-maximal inhibitory concentration: 4 nM
Compound 4: the middle estimate sits 5.0-fold (0.70 log units) above what was measured; the measured number lies below the stated range.
By their numbers in this assay, from the lowest: compounds 4 and 2 (each within the scatter of the next); then compounds 1 and 3 (each within the scatter of the next).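

The chain nitrogen accepts an aromatic ring bound directly to it, with no carbonyl or sulfonyl link: with 6-methoxypyrazin-2-yl in place of (thiophen-2-yl)carbonyl, this assay gives a 1.8-fold lower number from compound 2 to compound 4 (0.24 log units; within the scatter). With the same group in place of (1H-imidazol-4-yl)sulfonyl, the read-out shows a 5.8-fold lower number from compound 1 to compound 4 (0.76 log units; beyond the scatter), so the sensitivity at this nitrogen is now seen with a linker-free ring as well as with an amide. No measurement offered here accounts for either step.

Still open, going by these compounds, is what the methoxy contributes, since a pyrazin-2-yl ring without it, or with an amino group in its place, would separate the ring from its substituent. A pyridin-2-yl ring on this nitrogen and a longer chain also remain to be read against compound 4.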